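This account rests on a few compounds, and the source may have more. Where it says the series, first, only, none or still open, it means among the compounds named here.

Measured in a functional assay on U-373MG ATCC cells (Homo sapiens) for inhibition, read by MTT assay, with a stated time of 72 h; on this read-out higher numbers stand for weaker inhibition of growth and lower numbers for stronger inhibition of growth:
- compound 1 `CC1(C)CCC[C@]2(C)[C@@H](C=O)C(C=O)=CC[C@@H]12`: > 100000 nM (a limit of the assay)
- compound 2 `COC(=O)/C=C/C1=CC[C@H]2C(C)(C)CCC[C@]2(C)[C@H]1C=O`: 22000 nM

Within the data shown here, compound 2 holds the only actual number. Among the measured compounds shown here, the one measured step, an at least 4.5-fold lower number from compound 1 to compound 2 (0.65 log units; beyond the scatter), starts from a limit and concerns a different change, so it gives no size for the next one. Compound 3 `CCOC(=O)/C=C/C1=CC[C@H]2C(C)(C)CCC[C@]2(C)[C@H]1C=O` differs from compound 2 by methyl in place of hydrogen on a saturated chain carbon bound to an oxygen next to a carbonyl group, that is, methoxycarbonyl to ethoxycarbonyl. For the measured compounds named here, with no measured step covering this change, the estimate stays anchored on compound 2 at 22000 nM, and no change beyond the scatter is expected in this assay. The expected step is a 1.1-fold lower number from compound 2 to compound 3 (0.04 log units; within the scatter). The estimated value for compound 3 is 20000 nM, with an expected range of 8000 nM to 50000 nM.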

Compound 3, concentration for 50% growth inhibition: 37000 nM
Compound 3: middle estimate off by 1.9-fold (0.27 log units), on the low side; the measured number falls inside the stated range.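

In this assay, methyl in place of hydrogen on a saturated chain carbon bound to an oxygen next to a carbonyl group gives a 1.7-fold higher number from compound 2 to compound 3 (0.23 log units; within the scatter), so methoxycarbonyl to ethoxycarbonyl makes no difference that can be read here. The series also gives an at least 2.7-fold lower number from compound 1 to compound 3 (0.43 log units; beyond the scatter), so the replacement of formyl now holds for both esters. Both steps from compound 1 start from a limit of the assay: the limit of > 100000 nM in this assay, at which 1 of the 3 values shown sits.

Still open, as far as these compounds go, is whether a longer chain on the ester oxygen would leave the number within the scatter. From the compounds shown here alone, a carboxylic acid or an amide in place of the ester is equally open.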